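The compounds below may be only part of what the source reports. "The series", "measured", "known", "first", "only" and "open" are said of these compounds alone.

In a functional assay on B16 cells (Mus musculus) for antiproliferative activity, read by MTT assay, with a stated time of 24 h (a lower number here means a stronger inhibitor, a higher number a weaker inhibitor), compound 1 (`COc1cccc(C(=O)Oc2ccc3c(=O)c(-c4cc(OC)c(OC)cc4OC)coc3c2)c1`) gives > 10000 nM, which is a limit of the assay and not a number. Compound 1 therefore stands at the limit of > 10000 nM in this assay, at which 1 of the 2 values shown sits. Compound 2 (`COc1cc(OC)c(-c2coc3cc(OCc4ccccc4F)ccc3c2=O)cc1OC`), with 2-fluorobenzyl in place of (3-methoxyphenyl)carbonyl on an oxygen on an aromatic ring, gives 1610 nM. Compound 3 (`COc1cc(OC)c(-c2coc3cc(OCc4ccccc4C(F)(F)F)ccc3c2=O)cc1OC`) departs from compound 1 at the same place, with 2-(trifluoromethyl)benzyl entering instead: 2-(trifluoromethyl)benzyl in place of (3-methoxyphenyl)carbonyl on an oxygen on an aromatic ring. Going by the values given here, one measured step bears on this change, namely an at least 6.2-fold lower number from compound 1 to compound 2 (0.79 log units; beyond the scatter). It is beyond the scatter, and both benzyl groups replace the same (3-methoxyphenyl)carbonyl. Among the compounds with values here, no measured compound yet compares 2-(trifluoromethyl)benzyl with 2-fluorobenzyl directly, so a step of similar size and direction in this assay is only an expectation. The expected change is an at least 4.5-fold lower number from compound 1 to compound 3 (0.65 log units; beyond the scatter), toward a lower number and beyond the scatter. For compound 3 the estimated value is 2200 nM, with an expected range from 700 nM to 8000 nM.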

Compound 3, half-maximal inhibitory concentration: 8550 nM
For compound 3 the middle estimate is 3.9-fold (0.59 log units) below the measured one; measured number above the stated range.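

In this assay, the group on this oxygen turns out to matter in its detail and not merely as a benzyl group: trifluoromethyl in place of fluoro on an aromatic carbon gives a 5.3-fold higher number from compound 2 to compound 3 (0.73 log units; beyond the scatter), so the clear advantage of 2-fluorobenzyl does not carry over to 2-(trifluoromethyl)benzyl. Measured against the (3-methoxyphenyl)carbonyl of compound 1, the change to 2-(trifluoromethyl)benzyl gives only an at least 1.1-fold lower number from compound 1 to compound 3 (0.06 log units; that floor lies within the scatter), so this benzyl group cannot be said to improve on the starting compound by more than the scatter. Compound 1 stands at a limit of the assay and not at a number: the limit of > 10000 nM in this assay, at which 1 of the 3 values shown sits.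

The compounds shown leave open where a plain benzyl group, or a benzyl group carrying chloro, methoxy or nitrile in place of fluoro, would fall relative to compound 2 and compound 3. They also leave open how a chain ending in an amine on the same oxygen would compare, and what lies behind the step from fluoro to trifluoromethyl cannot be told from these values.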